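Hydrazone aryl swap in the triazole-thioacetohydrazide series

The source may hold more compounds than are shown below. What is called first, only, known or untested is meant among the compounds shown, and "the series" means these compounds.

Measured so far:
compound 1, `O=C(CSc1nnc(-c2ccncc2)n1-c1ccccc1)N/N=C/c1cc(Br)ccc1O`: 4390 nM
compound 2, `O=C(CSc1nnc(-c2ccncc2)n1-c1ccccc1)N/N=C/c1cc(Br)cc(Br)c1O`: 7590 nM

In a functional assay on HepG2 cells (Homo sapiens) for inhibition, read by MTT assay, with a stated time of 48 h (a higher number here means a weaker inhibitor, a lower number a stronger inhibitor), compound 1 gives 4390 nM and compound 2 gives 7590 nM. Among the compounds with values here, compound 2 holds the highest of the two numbers, but its only neighbour is compound 1, and the step of a 1.7-fold higher number from compound 1 to compound 2 (0.24 log units; within the scatter) lies within the scatter, so the two cannot be ordered.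

Compound 3, `O=C(CSc1nnc(-c2ccncc2)n1-c1ccccc1)N/N=C/c1ccc(O)c(O)c1`, is not yet measured. It differs from compound 2 by 3,4-dihydroxyphenyl in place of 3,5-dibromo-2-hydroxyphenyl on a carbon with a double bond to nitrogen. Within the data shown here, the one measured step, a 1.7-fold higher number from compound 1 to compound 2 (0.24 log units; within the scatter), concerns a single bromo and is within the scatter; it bears on the change only in part, since compound 3 loses both bromines and the hydroxyl changes place. Among the measured compounds shown here, no measured step covers that, so nothing beyond the scatter is expected in either direction in this assay. The step from compound 2 to compound 3 is estimated as a 1.4-fold lower number from compound 2 to compound 3 (0.14 log units; within the scatter). Compound 3 is therefore expected to give about 5500 nM, plausibly between 1500 nM and 20000 nM.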

Compound 3, half-maximal inhibitory concentration: 16900 nM
For compound 3 the middle estimate is 3.1-fold (0.49 log units) below the measured one; measured number inside the range.
By their numbers in this assay, from the lowest: compounds 1 and 2 (each within the scatter of the next); then compound 3.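

In this assay, within the data shown here, replacing the aryl group on the carbon with a double bond to nitrogen gives the first changes that lie beyond the scatter: 3,4-dihydroxyphenyl in place of 3,5-dibromo-2-hydroxyphenyl gives a 2.2-fold higher number from compound 2 to compound 3 (0.35 log units; beyond the scatter), and in place of 5-bromo-2-hydroxyphenyl it gives a 3.8-fold higher number from compound 1 to compound 3 (0.59 log units; beyond the scatter). Both steps are modest, but they show that this position can shift the number in a way the bromo step, a 1.7-fold higher number from compound 1 to compound 2 (0.24 log units; within the scatter), did not, and both run towards a weaker inhibitor. No data given here bear on the reason for this shift.

Each step combines loss of bromine with a different hydroxyl pattern, so the contribution of each part stays unresolved. Also open, from the compounds shown here alone, is how an amine or a carboxylic acid on this aryl ring would compare.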